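Swapping Pyridinyl for Benzyl on the Amide Nitrogen

A few compounds are considered here, and "the series" means these few. Any claim that something is new, unique, unknown or untested is made for them only; others in the source may bear on it.

Compound 1 `Cc1cc(C(N)=O)nn1Cc1cc(Cl)ccc1OCc1ccccc1` gives 126 nM in an assay on CHO-K1 cells for displacement of a labelled ligand from prostaglandin E2 receptor EP1 subtype (Homo sapiens); a higher number here means a weaker inhibitor, a lower number a stronger inhibitor.
Compound 2 `Cc1cc(C(=O)Nc2ccccn2)nn1Cc1cc(Cl)ccc1OCc1ccccc1` gives 126 nM in this assay.

Compound 2 stands level with compound 1 in this assay: putting pyridin-2-yl in place of hydrogen on the amide-type nitrogen, no change at the digits printed from compound 1 to compound 2 (within the scatter), moved nothing beyond the scatter. Compound 3 `Cc1cc(C(=O)NCc2ccccc2)nn1Cc1cc(Cl)ccc1OCc1ccccc1` is not yet measured; it differs from compound 2 by benzyl in place of pyridin-2-yl on an amide-type nitrogen. Among the compounds with values here, no measured pair shows this exact exchange. Within the data shown here, the only step that touches the same amide-type nitrogen, no change at the digits printed from compound 1 to compound 2 (within the scatter), shows the value holding steady when a six-membered aromatic ring was placed there. Because of no change at the digits printed from compound 1 to compound 2 (within the scatter) compound 3 is expected to sit close to compound 2, with no shift beyond the scatter in either direction. The expected step, a 1.0-fold higher number from compound 2 to compound 3 (0.01 log units; within the scatter), is therefore small. Compound 3 is estimated to give about 130 nM, within 50 nM to 350 nM.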

Compound 3, half-maximal inhibitory concentration: 39.8 nM
Compound 3: the middle estimate sits 3.3-fold (0.51 log units) above what was measured, outside the stated range (below it).
By their numbers in this assay, from the lowest: compound 3; then compounds 1 and 2 (each within the scatter of the next).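

The amide nitrogen is not indifferent to what it carries: in this assay, benzyl lowers the number both against pyridin-2-yl (a 3.2-fold lower number from compound 2 to compound 3 (0.50 log units; beyond the scatter)) and against the plain amide hydrogen (a 3.2-fold lower number from compound 1 to compound 3 (0.50 log units; beyond the scatter)). The unchanged value with pyridin-2-yl therefore did not mean that every six-membered aromatic ring placed here leaves the value alone, since benzyl also carries such a ring, though one of carbon only and held away from the nitrogen by a carbon link. Nothing measured explains why benzyl differs.

The exchange alters the ring and the link together, so the compounds shown cannot tell which of the two matters. A phenyl group on this nitrogen would separate them, and a 2-phenylethyl chain would show whether a longer link goes further.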